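A few compounds are considered here, and "the series" means these few. Any claim that something is new, unique, unknown or untested is made for them only; others in the source may bear on it.

Measured in a functional assay on MCF7 cells (Homo sapiens) for antiproliferative activity, read by MTT assay, with a stated time of 72 h; on this read-out lower numbers stand for stronger inhibition and higher numbers for weaker inhibition:
compound 1 `COc1ccc(N2CCN(C(=S)SCc3ccc4nc(N)nc(N)c4c3)CC2)cc1` gives 1580 nM
compound 2 `Nc1nc(N)c2cc(CSC(=S)N3CCN(c4ccc(Cl)cc4)CC3)ccc2n1` gives 4880 nM
compound 3 `Nc1nc(N)c2cc(CSC(=S)N3CCN(c4ccccc4Cl)CC3)ccc2n1` gives 3190 nM

Compound 1 holds the lowest of the three numbers, and compounds 2 and 3 both lie beyond the scatter from it. Next is compound 4 `Nc1nc(N)c2cc(CSC(=S)N3CCN(c4ccc(F)cc4)CC3)ccc2n1`, with fluoro in place of methoxy on an aromatic carbon, para to a large group: fluoro in place of methoxy on an aromatic carbon. The closest measured step is a 3.1-fold higher number from compound 1 to compound 2 (0.49 log units; beyond the scatter), where chloro replaces methoxy. The step of a 2.0-fold higher number from compound 1 to compound 3 (0.31 log units; beyond the scatter) runs in the same direction, while a 1.5-fold lower number from compound 2 to compound 3 (0.18 log units; within the scatter) leaves the two chloro compounds unseparated. Among the measured compounds shown here, no fluoro compound has been measured yet, so this guide is indirect. A modest rise in this assay is therefore expected, similar to or somewhat smaller than the chloro step. The estimated step is a 1.9-fold higher number from compound 1 to compound 4 (0.28 log units; within the scatter). For compound 4 the estimated value is 3000 nM, with an expected range from 1200 nM to 7000 nM.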

Compound 4, half-maximal inhibitory concentration: 1920 nM
The estimate for compound 4 lay 1.6-fold (0.19 log units) above the measured number, and the stated range covers the measured number.
By their numbers in this assay, from the lowest: compounds 1, 4, 3 and 2 (each within the scatter of the next, the first and the last beyond it).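

In this assay, fluoro on the aromatic carbon para to a large group cannot be separated from methoxy (a 1.2-fold higher number from compound 1 to compound 4 (0.08 log units; within the scatter)), whereas chloro at this place lay beyond the scatter from methoxy. The step between the two halogens at this place is also beyond the scatter (a 2.5-fold lower number from compound 2 to compound 4 (0.41 log units; beyond the scatter)), so the change from methoxy does not act alike for every halogen in these compounds. Among the compounds shown here, the 4-fluorophenyl group cannot be separated from the 2-chlorophenyl group (a 1.7-fold lower number from compound 3 to compound 4 (0.22 log units; within the scatter)), which leaves compound 2 as the only compound apart from compound 4.

As far as these compounds go, whether an amine, a hydroxyl or a nitrile at this place would stay level with methoxy and fluoro remains open. Nothing available bears on why fluoro and chloro part here.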